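The source may report more compounds than this note shows. Statements on the series, on what has been measured and on what is new or still open speak of the compounds shown alone.

Measured so far:
Compound 1 `COc1ccccc1/C=C/C(=O)/C=C/c1ccc(OCc2cn(CCCOc3cc(=O)oc4ccccc34)nn2)c(OC)c1`: 50%
Compound 2 `COc1cc(/C=C/C(=O)/C=C/c2ccco2)ccc1OCc1cn(CCCCOc2cc(=O)oc3ccccc23)nn1`: 49%

Within the data shown here, only two compounds have been measured in a functional assay on THP-1 cells (Homo sapiens) for inhibition, read by sulforhodamine B assay, with a stated time of 48 h, tested at 50 uM; a lower number here means less inhibition of growth, a higher number more inhibition of growth at the concentration tested. Compound 1 gives 50% and compound 2 gives 49%. These two numbers lie within the scatter of each other, so compound 1 stands level with compound 2 and neither can be ranked above the other.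

The next compound to be tested is compound 3 `COc1cc(/C=C/C(=O)/C=C/c2cccs2)ccc1OCc1cn(CCCOc2cc(=O)oc3ccccc23)nn1`. Its difference from compound 1 is thiophen-2-yl in place of 2-methoxyphenyl on a double-bonded chain carbon bound to a double-bonded chain carbon. In other words, thiophen-2-yl takes the place of 2-methoxyphenyl on a double-bonded chain carbon bound to a double-bonded chain carbon, and the rest of the structure stays the same.

Among the measured compounds shown here, no step between measured compounds is available to show what such an exchange does in this assay, so the only guide is the level set by the two values. No change beyond the scatter is expected, and no direction is favoured. The estimated step of a number 2 percentage points lower from compound 1 to compound 3 (within the scatter) therefore stays small. For compound 3 the expected value is 48%, within an estimated range of 35% to 61%.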

Compound 3, percent growth inhibition at one concentration: 54%
For compound 3 the middle estimate is 6 percentage points below the measured one, within the range that was stated.
By their numbers in this assay, from the lowest: compounds 2, 1 and 3 (each within the scatter of the next).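

In this assay, among these compounds, this is the first step that can be read at this position: thiophen-2-yl in place of 2-methoxyphenyl on a double-bonded chain carbon bound to a double-bonded chain carbon gives a number 4 percentage points higher from compound 1 to compound 3 (within the scatter) in growth inhibition at the concentration tested. The position therefore accepts a five-membered aromatic ring with 1 hetero atom and 5 heavy atoms in place of a six-membered aromatic ring of carbon only with 8 heavy atoms, and the result stays within the scatter, even though the sulfur of the entering group replaces a ring with a methoxy group on it. No measured information bears on why the two compounds read alike, so this single exchange supports no explanation of the result.

As far as these compounds go, whether an amine or a carboxylic acid carried on the aromatic ring at this position would also leave the number within the scatter remains open. From the compounds shown here alone, the effect of chain length also remains open, since compound 2 carries a longer chain but differs from compound 1 and compound 3 in more than one place, so a single step for a butyl or a longer chain cannot be read from these compounds.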